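Swapping Bromo for Chloro in a Channel Antagonist Series

A few compounds are considered here, and "the series" means these few. Any claim that something is new, unique, unknown or untested is made for them only; others in the source may bear on it.

Compound 1, `O=C(Nc1ccccc1Br)N[C@@H]1CCN(c2ccc(Br)cn2)C1`: 7.2
Compound 2, `O=C(NCCN1CCc2c(F)cccc21)Nc1ccccc1Br`: 7.4

Of the compounds shown here, two have been measured in a functional assay for antagonist activity at transient receptor potential cation channel subfamily V member 1 (Rattus norvegicus), read by FLIPR; on this read-out lower numbers stand for lower potency and higher numbers for higher potency (the scale is a negative logarithm). Compound 1 gives 7.2, and compound 2 gives 7.4. Compound 1 holds the lower of the two numbers, but the gap to compound 2 lies within the usual scatter of this kind of measurement, so the two cannot be told apart on these data. Among the measured compounds shown here, no pair of measured compounds differs in just one place, so no single structural step has yet been put to the test.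

Compound 3, `O=C(Nc1ccccc1Br)N[C@@H]1CCN(c2ccc(Cl)cn2)C1`, differs from compound 1 in one spot: chloro in place of bromo on an aromatic carbon. For the measured compounds named here, with no measured step to lean on, the expectation rests on the change being a swap of one halogen for another at the same aromatic carbon. The step from compound 1 to compound 3 is expected to be a number 0.20 log units lower from compound 1 to compound 3 (within the scatter), that is, no change beyond the scatter. Compound 3 is therefore estimated at 7, with a likely range from 6.5 to 7.5.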

Compound 3, negative logarithm of the antagonist equilibrium constant: 7.3
For compound 3 the middle estimate is 0.30 log units below the measured one; low and high end bracket the measured number.
By their numbers in this assay, from the lowest: compounds 1, 3 and 2 (each within the scatter of the next).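

In this assay, the change from 5-bromopyridin-2-yl to 5-chloropyridin-2-yl gives a number 0.10 log units higher from compound 1 to compound 3 (within the scatter). Among the compounds shown here, this is the first single-place comparison, and it shows that, at this position on the core of compound 1, chloro and bromo cannot be told apart in this measurement. No measurement offered here explains why the two halogens read alike.

The compounds shown leave open whether this position would also accept a group that is not a halogen, such as a methyl, a nitrile or an amine, since both groups compared here are single halogen atoms. They also leave open whether the same swap would read the same way at the other bromo, which stays in place in both compound 1 and compound 3.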